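A few compounds are considered here, and "the series" means these few. Any claim that something is new, unique, unknown or untested is made for them only; others in the source may bear on it.

Of the compounds shown here, three have been tested in an assay on PC-12 cells for displacement of a labelled ligand from vesicular acetylcholine transporter (Homo sapiens) (a lower number here means a stronger inhibitor, a higher number a weaker inhibitor), all built around the same core. Compound 1 `OC1CN(Cc2ccc(Br)cc2)CCC1N1CCN(c2ccccc2)CC1` carries a 4-bromobenzyl group on the ring nitrogen of the piperidine. In this assay compound 1 gives > 100 nM, which is a limit of the assay rather than a number. Compound 2 `C=CCN1CCC(N2CCN(c3ccccc3)CC2)C(O)C1`, with an allyl group in that place, gives > 100 nM, again a limit. The step that the two limits leave unreadable from compound 1 to compound 2 therefore cannot be read. Compound 3 `OC1CCNCC1N1CCN(c2ccccc2)CC1` has only a hydrogen on that ring nitrogen and gives > 100 nM, a limit as well, so compound 3 stands where every measured compound stands: at the limit of > 100 nM in this assay, at which 3 of the 3 values shown sit.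

Compound 4 `OC1CCN(Cc2ccccc2)CC1N1CCN(c2ccccc2)CC1` differs from compound 3 by benzyl in place of hydrogen on an amine nitrogen in a ring. Within the data shown here, no measured step tells how such a change acts, since every value so far is a limit. Given that compounds 1, 2 and 3 all sit at the limit, the step that the limit leaves unreadable from compound 3 to compound 4 is expected to be small, and compound 4 is estimated at 300 nM, within 80 nM to 3000 nM, most likely again only a limit.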

Compound 4, half-maximal inhibitory concentration: > 100 nM
Compound 4 was reported as a limit (the forecaster's own chance of this, stated with the estimate: 75%); the middle value is on the limit's open side.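

In this assay compound 4 gives > 100 nM, which is a limit of the assay. Compound 3 also sits at a limit, so the step between compound 3 and compound 4 cannot be read. The compounds shown leave open whether any group on that amine nitrogen changes inhibition, because none yet has a true number: the limit of > 100 nM in this assay, at which 4 of the 4 values shown sit.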